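Ring Swap on the Chain: Aromatic to Saturated Cation

A few compounds are considered here, and "the series" means these few. Any claim that something is new, unique, unknown or untested is made for them only; others in the source may bear on it.

Compound 1 `Cc1cc(OCCCCCCC[n+]2ccccc2)cc(-n2cc(C(=O)Nc3cc(F)cc(F)c3)c(=O)c3ccc(N(C)C)nc32)c1`: in an assay on LX2 cells for inhibition of COL1A1 promoter (Homo sapiens), read by a luciferase reporter, with a stated time of 24 h, tested at 20 uM (on this read-out lower numbers stand for a weaker effect and higher numbers for a stronger effect at the one concentration tested), compound 1 gives 7.7%.
Compound 2 `CN(C)c1ccc2c(=O)c(C(=O)Nc3cc(F)cc(F)c3)cn(-c3ccc(Cl)c(OCCCCCCC[n+]4ccccc4)c3)c2n1`: in this assay compound 2 is reported as "not active" (no number reported).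
Compound 3 `CC[N+]1(CCCCCCCOc2cc(C)cc(-n3cc(C(=O)Nc4cc(F)cc(F)c4)c(=O)c4ccc(N(C)C)nc43)c2)CCCCC1`: in this assay compound 3 gives 67.2%.

Compounds 1 and 3 share one core and differ in a single place: a group of 8 heavy atoms (7 carbon, 1 nitrogen; one six-membered non-aromatic ring with 1 hetero atom) in place of a group of 6 heavy atoms (5 carbon, 1 nitrogen; one six-membered aromatic ring with 1 hetero atom), on a saturated chain carbon, seven bonds along the chain from an oxygen on an aromatic ring. This change gave a number 59.5 percentage points higher from compound 1 to compound 3 (beyond the scatter).

Compound 4 `CC[N+]1(CCCCCCCOc2cc(-n3cc(C(=O)Nc4cc(F)cc(F)c4)c(=O)c4ccc(N(C)C)nc43)ccc2Cl)CCCCC1` has not yet been measured. It stands to compound 2 exactly as compound 3 stands to compound 1, the same change at the same place: a group of 8 heavy atoms (7 carbon, 1 nitrogen; one six-membered non-aromatic ring with 1 hetero atom) in place of a group of 6 heavy atoms (5 carbon, 1 nitrogen; one six-membered aromatic ring with 1 hetero atom), on a saturated chain carbon, seven bonds along the chain from an oxygen on an aromatic ring. The difference between the core of compound 2 and the core of compound 1 is not broken down here. Compound 2 itself is reported as not active in this assay, without a number, so the starting point of the step is less certain than for compound 1.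

Because the same change produced a number 59.5 percentage points higher from compound 1 to compound 3 (beyond the scatter), a rise of comparable direction is expected for compound 4, though a cautious one given the core difference. For compound 4 an inhibition of about 35% is estimated, within a range of 0% to 70%.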

Compound 4, a percentage reported as inhibition, at one concentration (the size of the read-out at that concentration, not a potency): "not active" (no number reported)
Nothing numeric was reported for compound 4; no gap can be computed for the estimate.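

Compound 2 and compound 4 are both reported as not active in this assay, with no number, so no step can be read between them. Left open is whether the swap to the saturated ring has any effect on the core of compound 2. No measurement shown here offers an explanation for this result.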